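A few compounds are considered here, and "the series" means these few. Any claim that something is new, unique, unknown or untested is made for them only; others in the source may bear on it.

Two pairs of compounds were examined in an assay on HEK293 cells for inhibition of Toll-like receptor 8 (Homo sapiens), with a stated time of 16 h; a lower number here means a stronger inhibitor, a higher number a weaker inhibitor. Compound 1 `N#Cc1c(Cl)cccc1Oc1ccc(-c2nnco2)cc1` gives 1400 nM in this assay. Compound 2 `O=C(Nc1ccc(Oc2cc(Cl)cc(C(F)(F)F)c2)cc1)c1c(F)cccc1Cl` gives 2040 nM, and compound 3 `O=C(Nc1ccc(Oc2cc(Br)cc(C(F)(F)F)c2)cc1)c1c(F)cccc1Cl` gives 2320 nM; how the core of compound 1 differs from the core of compound 2 is not broken down here. Compound 3 carries bromo in place of chloro on an aromatic carbon, a change that produced a 1.1-fold higher number from compound 2 to compound 3 (0.06 log units; within the scatter). Compound 4 `N#Cc1c(Br)cccc1Oc1ccc(-c2nnco2)cc1`, not yet measured, carries bromo in place of chloro on an aromatic carbon. This is the same kind of change, although the surroundings differ: in compound 4 the place is ortho to a cyano group and meta to a large group, whereas in compound 3 it is meta to a large group and meta to a trifluoromethyl group. Resting on a 1.1-fold higher number from compound 2 to compound 3 (0.06 log units; within the scatter), the corresponding step is expected to be a 1.1-fold higher number from compound 1 to compound 4 (0.04 log units; within the scatter). Compound 4 is therefore estimated at 1550 nM, with a range from 800 nM to 3000 nM.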

Compound 4, half-maximal inhibitory concentration: 880 nM
Beside the measured number, compound 4's estimate is 1.8-fold (0.25 log units) above it, and the stated range covers the measured number.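

In this assay, bromo in place of chloro on the core of compound 1 gave a 1.6-fold lower number from compound 1 to compound 4 (0.20 log units; within the scatter). Set beside the earlier case, the two steps do not differ: the same change on two cores in this assay, a 1.1-fold higher number (0.06 log units; within the scatter) from compound 2 to compound 3 and a 1.6-fold lower number (0.20 log units; within the scatter) from compound 1 to compound 4, 1.8-fold (0.26 log units) apart, within the scatter of two such steps. This shows that the change behaved alike on these two cores, but each step lies within the scatter, so it shows neither a gain nor a loss on either core, and two pairs say nothing about other cores in the series.

Still open, on these data alone, is whether a methyl or a methoxy in that place would read like the two halogens. Also open, as far as these compounds go, is whether an amine in place of the cyano group would leave the step unchanged.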